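Swapping the aryl group on a sulfonamide nitrogen

The source may hold more compounds than are shown below. What is called first, only, known or untested is meant among the compounds shown, and "the series" means these compounds.

Of the compounds shown here, three built on one shared core have been tested in a functional assay on MCF7 cells (Homo sapiens) for antiproliferative activity, read by sulforhodamine B assay, with a stated time of 48 h; on this read-out lower numbers stand for stronger inhibition and higher numbers for weaker inhibition. Compound 1 `Cc1cccc(NS(=O)(=O)c2ccc(N3CCNC3=O)cc2)c1` gives 190 nM in this assay. Compound 2 `O=C1NCCN1c1ccc(S(=O)(=O)Nc2ccc(OC(F)F)cc2)cc1` gives 760 nM, and compound 3 `O=C1NCCN1c1ccc(S(=O)(=O)Nc2ccc3c(c2)CCC3)cc1` gives 240 nM. Compound 1 holds the lowest of the three numbers, but its gap to compound 3 lies within the usual scatter of such measurements, so the two cannot be ranked against each other; only its gap to compound 2 is wide enough to count as a real difference.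

The next compound, compound 4 `COc1ccccc1NS(=O)(=O)c1ccc(N2CCNC2=O)cc1`, departs from compound 1 at a single spot: 2-methoxyphenyl in place of 3-methylphenyl on a sulfonamide nitrogen. Among the compounds with values here, no measured pair in this set shows exactly that kind of change, so there is no direct step to lean on. The three aryl groups already seen, a methylphenyl, a bicyclic ring system and a difluoromethoxyphenyl, give numbers spread across a modest range, with the oxygen-bearing group the weakest of them.

On that basis a small loss, or no change beyond the scatter, is expected for compound 4, with an estimate of 320 nM in this assay and a likely range from 120 nM to 850 nM. The step this estimate implies is a 1.7-fold higher number from compound 1 to compound 4 (0.23 log units; within the scatter).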

Compound 4, half-maximal inhibitory concentration: 770 nM
The estimate for compound 4 lay 2.4-fold (0.38 log units) below the measured number; the measured number falls inside the stated range.
By their numbers in this assay, from the lowest: compounds 1 and 3 (each within the scatter of the next); then compounds 2 and 4 (each within the scatter of the next).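

In this assay, the direct step here is a 4.1-fold higher number from compound 1 to compound 4 (0.61 log units; beyond the scatter), and because it lies beyond the usual scatter, it shows that the aryl group on the sulfonamide nitrogen can change the result and that this replacement weakens inhibition. The swap changes two things at once: the substituent goes from methyl to methoxy, adding an oxygen and a hydrogen-bond acceptor, and its numbered ring position also changes, so this single step cannot show which change matters. No available evidence bears on why the number rises.

Two other aryl groups, 2-methylphenyl and 3-methoxyphenyl, would help pull those two changes apart, since each keeps one feature of 3-methylphenyl and one of 2-methoxyphenyl. From the compounds shown here alone, it also remains open how a phenyl ring carrying an amine or a carboxylic acid would behave on this sulfonamide nitrogen, and whether any such group could bring the number below that of compound 1, which stands at 190 nM.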